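Moving the methoxy group on compound 3

A few compounds are considered here, and "the series" means these few. Any claim that something is new, unique, unknown or untested is made for them only; others in the source may bear on it.

Measured so far in a functional assay (Left cardiac atrium, Cavia porcellus), with a stated time of 30 min; a higher number here means that more compound is needed for the effect, a lower number that less compound is needed
Compound 1 `CCOC1(c2cccc(OC)c2)SC=C(C)n2c1noc2=O` gives 38 nM
Compound 2 `COc1cccc(C2(OCC(F)(F)F)SC=C(C)n3c2noc3=O)c1` gives 320 nM
Compound 3 `COc1cccc(C2(OCC3CCCCC3)SC=C(C)n3c2noc3=O)c1` gives 650 nM

Compound 3 has the highest number of the three, so it needs the most compound for the effect. The steps of a 17-fold higher number from compound 1 to compound 3 (1.23 log units; beyond the scatter) and a 2.0-fold higher number from compound 2 to compound 3 (0.31 log units; beyond the scatter) both lie beyond the usual scatter.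

The next compound, compound 4 `COc1ccccc1C1(OCC2CCCCC2)SC=C(C)n2c1noc2=O`, has the same atoms joined differently, with 2-methoxyphenyl in place of 3-methoxyphenyl on a saturated ring carbon. Within the data shown here, no measured step tests this change directly. The steps seen so far, which include an 8.4-fold higher number from compound 1 to compound 2 (0.93 log units; beyond the scatter) and the two above, only alter the group on a saturated chain carbon bound to an oxygen. They show that a single change in this series can be modest or large in this assay, but they say nothing about direction for the methoxy group. The central expectation is therefore no step beyond the scatter, with wide allowance on either side. The expected step is a 1.1-fold higher number from compound 3 to compound 4 (0.03 log units; within the scatter) and remains only an estimate. Compound 4 is estimated at 700 nM within an expected range of 180 nM to 2700 nM until it is measured.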

Compound 4, half-maximal effective concentration: 480 nM
The estimate for compound 4 lay 1.5-fold (0.16 log units) above the measured number; low and high end bracket the measured number.
By their numbers in this assay, from the lowest: compound 1; then compounds 2, 4 and 3 (each within the scatter of the next, the first and the last beyond it).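

In this assay, a 1.4-fold lower number from compound 3 to compound 4 (0.13 log units; within the scatter) is a step within the usual scatter, so 2-methoxyphenyl and 3-methoxyphenyl cannot be told apart at this saturated ring carbon next to the ring sulfur. Among these compounds, the earlier steps changed only the group on the saturated chain carbon bound to an oxygen, and one of them reached a 17-fold higher number from compound 1 to compound 3 (1.23 log units; beyond the scatter); this pair is the first to change the aromatic group instead, and with the same atoms joined differently it shows no step beyond the scatter. Among the compounds shown here, the finding covers only this one pair, both members of which carry the cyclohexyl group, and no supporting measurement is available to explain it.

From the compounds shown here alone, whether the two methoxyphenyl groups would also match alongside the smaller group on the oxygen in compound 1, where this assay gives the lowest number so far, remains open. Also open, going by these compounds, is what happens when the methoxy group is replaced altogether, for example by an amine or a carboxylic acid, or removed to leave plain phenyl.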